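This account rests on a few compounds, and the source may have more. Where it says the series, first, only, none or still open, it means among the compounds named here.

Compound 1, `Cc1cc(NC(=O)Nc2ccc(Cl)c(Cl)c2)c2ccccc2n1`, gives > 25000 nM.
Compound 2, `CCc1ccc(NC(=O)Nc2cc(C)nc3ccccc23)cc1`, gives 16000 nM.
Compound 3, `COc1ccccc1NC(=O)Nc1cc(C)nc2ccccc12`, gives > 25000 nM.

The measurements come from an ADME assay on HEK293 cells (Homo sapiens) for cytotoxicity, with a stated time of 72 h; a higher number here means that more compound is needed for the effect, a lower number that less compound is needed. In this assay compound 1 returns only a limit rather than a number, > 25000 nM. That limit is the limit of > 25000 nM in this assay, at which 2 of the 3 values shown sit. Compound 3 likewise returns only a limit, > 25000 nM. Compound 2 alone gives a number, 16000 nM. The account follows compound 1 to compound 4, `Cc1cc(NC(=O)Nc2cccc(Cl)c2)c2ccccc2n1`, not yet measured. The change is hydrogen in place of chloro on an aromatic carbon. Going by the values given here, no step between measured compounds is available for such a change, so the expectation rests on where compound 1 itself sits. Compound 4 is expected to show no step beyond the scatter in this assay, estimated as a number no higher from compound 1 to compound 4 (the limit leaves the size open). The estimate for compound 4 is 25000 nM, with a range from 12000 nM to 50000 nM.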

Compound 4, half-maximal effective concentration: 21000 nM
Estimate against measurement, compound 4: 1.2-fold (0.08 log units) above; the measured number falls inside the stated range.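

Hydrogen in place of chloro on this aromatic carbon, para to a large group, gives in this assay an at least 1.1-fold lower number from compound 1 to compound 4 (0.07 log units; that floor lies within the scatter). Going by these compounds alone, this is the first reading of a change at this position, and it turns a limit into a number, so compound 4 can be placed on the scale. The true size of the step stays open, since one end of it is only a limit: the limit of > 25000 nM in this assay, at which 2 of the 4 values shown sit.

The compounds shown leave open how an amine or a carboxylic acid on this carbon would read. They also leave open what hydrogen in place of the remaining chloro of compound 4 would give.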